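A few compounds are considered here, and "the series" means these few. Any claim that something is new, unique, unknown or untested is made for them only; others in the source may bear on it.

Measured in a functional assay on DU-145 cells (Homo sapiens) for antiproliferative activity, read by propidium iodide staining, with a stated time of 96 h; a higher number here means a weaker inhibitor, a lower number a stronger inhibitor:
- compound 1 `CC(O)(CSc1ccc(S(F)(F)(F)(F)F)cc1)C(=O)Nc1ccc([N+](=O)[O-])c(C(F)(F)F)c1`: 13900 nM
- compound 2 `CC(O)(CSc1ccc(S(F)(F)(F)(F)F)cc1)C(=O)Nc1ccc(S(F)(F)(F)(F)F)cc1`: 22300 nM
- compound 3 `CC(O)(CSc1cccc(S(F)(F)(F)(F)F)c1)C(=O)Nc1ccc(S(F)(F)(F)(F)F)cc1`: 17300 nM

Compound 3, at 17300 nM, holds the middle place of the three numbers, but it lies within the scatter of both compound 1 and compound 2, so these values cannot be told apart. In compound 4 `CC(O)(CSc1cccc(OC(F)(F)F)c1)C(=O)Nc1ccc(S(F)(F)(F)(F)F)cc1`, trifluoromethoxy replaces the group of 6 heavy atoms of compound 3, on an aromatic carbon, meta to a large group (a group of 5 heavy atoms (1 carbon, 1 oxygen, 3 fluorine; no ring) in place of a group of 6 heavy atoms (5 fluorine, 1 sulfur; no ring), on an aromatic carbon). Among the measured compounds shown here, no measured pair differs in one place, so the series offers no direct guide to this change. In this assay, no step beyond the scatter is expected. The expected step is a 1.0-fold higher number from compound 3 to compound 4 (0.02 log units; within the scatter). The estimate for compound 4 is 18000 nM, with an expected range of 9000 nM to 35000 nM.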

Compound 4, half-maximal inhibitory concentration: 23800 nM
The estimate for compound 4 lay 1.3-fold (0.12 log units) below the measured number; the measured number falls inside the stated range.
By their numbers in this assay, from the lowest: compounds 1, 3, 2 and 4 (each within the scatter of the next).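

Trifluoromethoxy in place of the group of 6 heavy atoms (5 fluorine, 1 sulfur), on an aromatic carbon meta to a large group, gives the only single-place step shown in this assay: a 1.4-fold higher number from compound 3 to compound 4 (0.14 log units; within the scatter). At this position, the two groups cannot be told apart in this read-out. No measured evidence bears on this result. As far as these compounds go, whether an amine or a carboxylic acid at this position would give a step beyond the scatter remains open, as does whether the same exchange reads alike elsewhere on the shared core.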